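The source may report more compounds than this note shows. Statements on the series, on what has been measured and on what is new or still open speak of the compounds shown alone.

Measured so far in a functional assay on MGC-803 cells (Homo sapiens) for inhibition, read by sulforhodamine B assay; a higher number here means a weaker inhibitor, a lower number a stronger inhibitor:
- compound 1 `COc1ccc(NC2=CC(=O)c3c(nc4n3[C@H]3OC[C@@H](O)[C@H]3OC4)C2=O)cc1`: 2150 nM
- compound 2 `CCCN(CCC)C1=CC(=O)c2c(nc3n2[C@H]2OC[C@@H](O)[C@H]2OC3)C1=O`: > 16000 nM, a limit of the assay and not a number

Compound 2 has no exact place on the scale, and it sits at the limit of > 16000 nM in this assay, at which 1 of the 2 values shown sits.

Compound 3 `O=C1C(Nc2cccc(F)c2)=CC(=O)c2c1nc1n2[C@H]2OC[C@@H](O)[C@H]2OC1` has not yet been measured. It carries (3-fluorophenyl)amino in place of dipropylamino on a double-bonded ring carbon. For the measured compounds named here, one measured step bears on this change: an at least 7.4-fold higher number from compound 1 to compound 2 (0.87 log units; beyond the scatter). That step lies beyond the scatter and runs the opposite way, with dipropylamino in place of (4-methoxyphenyl)amino. Going by the values given here, the group entering compound 3 resembles the one in compound 1, but the two are not the same, so the size of the change is uncertain. A move to a lower number in this assay is expected, of about the size of that step: an at least 6.4-fold lower number from compound 2 to compound 3 (0.80 log units; beyond the scatter). The estimated value for compound 3 is 2500 nM, with an expected range from 800 nM to 8000 nM.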

Compound 3, half-maximal inhibitory concentration: 1470 nM
The estimate for compound 3 lay 1.7-fold (0.23 log units) above the measured number; the range from low to high includes it.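

In this assay, (3-fluorophenyl)amino on the double-bonded ring carbon gives an at least 10-fold lower number from compound 2 to compound 3 (1.03 log units; beyond the scatter), so a second phenylamino group stands well clear of dipropylamino at this position. Compound 2 carries a limit of the assay and not a number, so this step gives only a minimum size: the limit of > 16000 nM in this assay, at which 1 of the 3 values shown sits. The two phenyl groups on the amine nitrogen give a 1.5-fold lower number from compound 1 to compound 3 (0.17 log units; within the scatter), which lies within the scatter, so 3-fluorophenyl and 4-methoxyphenyl cannot be told apart here.

Dipropylamino differs from both phenylamino groups in two ways, as it has no ring and no hydrogen on the nitrogen, and the compounds shown leave open which of these goes with the step. A propylamino group, which keeps that hydrogen without a ring, or an N-methylanilino group, which keeps the ring without it, could separate the two.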